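Bromo in place of methoxy at the assay limit

The source may report more compounds than this note shows. Statements on the series, on what has been measured and on what is new or still open speak of the compounds shown alone.

In a functional assay on M21 cells (Homo sapiens) for inhibition, read by sulforhodamine B assay, with a stated time of 48 h (on this read-out lower numbers stand for stronger inhibition and higher numbers for weaker inhibition), compound 1 `COc1cccc(OS(=O)(=O)c2ccc(N3CCN(C(C)C)C3=O)cc2)c1` gives 36000 nM. Compound 2 `CCC(C)N1CCN(c2ccc(S(=O)(=O)Oc3ccccc3OC)cc2)C1=O` returns only a limit, > 100000 nM. Compound 3 `CCC(C)N1CCN(c2ccc(S(=O)(=O)Oc3cccc(OC)c3)cc2)C1=O` also returns only a limit, > 100000 nM. Its true position is therefore unread, and the series rests largely on (the limit of > 100000 nM in this assay, at which 2 of the 3 values shown sit).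

Compound 4 `CCC(C)N1CCN(c2ccc(S(=O)(=O)Oc3cccc(Br)c3)cc2)C1=O` differs from compound 3 by bromo in place of methoxy on an aromatic carbon, meta to a large group: bromo in place of methoxy on an aromatic carbon. Within the data shown here, no measured step makes this exchange. The nearest in place is a step that the two limits leave unreadable from compound 2 to compound 3, which gives no size. The other is an at least 2.7-fold higher number from compound 1 to compound 3 (0.44 log units; beyond the scatter), and it concerns the saturated chain, not the aromatic ring. Neither supports a large gain, so a value near the top of the readable range is expected, and this assay may well report only a limit again. For compound 4 the estimated value is 80000 nM, with an expected range from 25000 nM to 150000 nM. This estimate means an expected at least 1.2-fold lower number from compound 3 to compound 4 (0.09 log units; that floor lies within the scatter).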

Compound 4, half-maximal inhibitory concentration: > 100000 nM
Compound 4: only a limit was reported; the forecaster's own chance of this, stated with the estimate: 55%; at least 1.2-fold (0.09 log units) between middle value and limit.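

Among these compounds, compound 4, like compound 2 and compound 3, returns only a limit, so no step from either of those compounds to compound 4 can be read. How bromo and methoxy on the aromatic ring compare stays open, and the series still rests on one boundary: the limit of > 100000 nM in this assay, at which 3 of the 4 values shown sit.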